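The source may hold more compounds than are shown below. What is called first, only, known or untested is meant among the compounds shown, and "the series" means these compounds.

Measured so far:
compound 1, `COc1ccc(/C=C2\CN(Cc3cn(Cc4ccc(F)cc4)nn3)C/C(=C\c3ccc(OC)cc3)C2=O)cc1`, 67500 nM
compound 2, `O=C1/C(=C/c2ccccc2F)CN(Cc2cn(Cc3ccccc3Cl)nn2)C/C1=C\c1ccccc1F`, 7100 nM
compound 3, `COc1ccc(/C=C2\CN(Cc3cn(Cc4ccccc4Cl)nn3)C/C(=C\c3ccc(OC)cc3)C2=O)cc1`, 36300 nM

All three numbers come from a functional assay on PC-3 cells (Homo sapiens) for cytotoxicity, read by MTT assay, with a stated time of 24 h; on this read-out lower numbers stand for stronger inhibition and higher numbers for weaker inhibition. Compound 2 gives the lowest number of the three; compound 3 stands nearest to it and compound 1 furthest, both gaps beyond the usual scatter. The difference between the cores of compound 2 and compound 3 is not broken down here. Compound 3 to compound 1 is a single change, (4-fluorophenyl in place of 2-chlorophenyl on a saturated chain carbon bound to an aromatic nitrogen), and it made a 1.9-fold higher number from compound 3 to compound 1 (0.27 log units; within the scatter). Compound 4, `O=C1/C(=C/c2ccccc2F)CN(Cc2cn(Cc3ccc(F)cc3)nn2)C/C1=C\c1ccccc1F`, is not yet measured; it carries the same change on the core of compound 2: 4-fluorophenyl in place of 2-chlorophenyl on a saturated chain carbon bound to an aromatic nitrogen. In this assay a step of similar small size is expected from compound 2 to compound 4, a 1.5-fold higher number from compound 2 to compound 4 (0.19 log units; within the scatter), because a 1.9-fold higher number from compound 3 to compound 1 (0.27 log units; within the scatter) stayed within the scatter, though this rests on one earlier instance only. Compound 4 is estimated at 11000 nM in this assay, expected to fall between 5000 nM and 25000 nM.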

Compound 4, half-maximal inhibitory concentration: 19400 nM
The estimate for compound 4 lay 1.8-fold (0.25 log units) below the measured number, within the range that was stated.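

The change from 2-chlorobenzyl to 4-fluorobenzyl gives a 2.7-fold higher number from compound 2 to compound 4 (0.44 log units; beyond the scatter) in this assay. Set beside the earlier step, the change carries over between the two cores without a detectable difference in size: the same change on two cores in this assay, a 1.9-fold higher number (0.27 log units; within the scatter) from compound 3 to compound 1 and a 2.7-fold higher number (0.44 log units; beyond the scatter) from compound 2 to compound 4, 1.5-fold (0.17 log units) apart, within the scatter of two such steps. This rests on two cores only, and it shows neither that the step would hold on other cores nor why the numbers differ; only the new step lies beyond the scatter.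

Still open, on these data alone, is whether the identity of the halogen or its place on the ring accounts for the step, as the two change together in both pairs. An unsubstituted benzyl or a longer phenylethyl chain at this place would extend the comparison.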